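The source may hold more compounds than are shown below. What is called first, only, known or untested is meant among the compounds shown, and "the series" means these compounds.

Series on the shared core of compound 1 `CCN(Cc1ccccc1)C(=O)C1CCN(S(=O)(=O)c2ccc3[nH]ncc3c2)CC1` in a functional assay on CHO cells for positive allosteric modulation of muscarinic acetylcholine receptor M5 (Homo sapiens), read by calcium flux (a higher number here means a larger maximal response, a lower number a smaller maximal response), where compound 1 gives 86%. Compound 2 `CCN(Cc1ccccc1Cl)C(=O)C1CCN(S(=O)(=O)c2ccc3[nH]ncc3c2)CC1` gives 78% and compound 3 `CCN(Cc1ccccc1C(F)(F)F)C(=O)C1CCN(S(=O)(=O)c2ccc3[nH]ncc3c2)CC1` gives 96%. Compound 3 holds the highest of the three numbers: the step of a number 10 percentage points higher from compound 1 to compound 3 (within the scatter) is within the scatter, while a number 18 percentage points higher from compound 2 to compound 3 (beyond the scatter) is beyond it; for completeness, a number 8 percentage points lower from compound 1 to compound 2 (within the scatter) is within the scatter. Compound 4 `CCC(C)N(Cc1ccccc1C(F)(F)F)C(=O)C1CCN(S(=O)(=O)c2ccc3[nH]ncc3c2)CC1` differs from compound 3 by ethyl in place of hydrogen on a saturated chain carbon bound to an amide-type nitrogen and a saturated chain carbon. Going by the values given here, every measured step alters the aromatic substituent; none touches the chain on the amide-type nitrogen, so no measured step bears directly on this change. No step beyond the scatter is therefore expected in this assay for compound 4, meaning a number 3 percentage points lower from compound 3 to compound 4 (within the scatter) is estimated. Compound 4 is expected to give 93%, within 74% to 108%.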

Compound 4, largest response reached (reported as percent of maximum), in percent of the reference or control that the assay uses: 100%
Compound 4: the middle estimate sits 7 percentage points below what was measured, within the range that was stated.
By their numbers in this assay, from the lowest: compounds 2, 1, 3 and 4 (each within the scatter of the next, the first and the last beyond it).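

First reading on the chain at the amide-type nitrogen: in this assay, ethyl in place of hydrogen on this saturated chain carbon, which turns ethyl into sec-butyl, gives a number 4 percentage points higher from compound 3 to compound 4 (within the scatter) on the trifluoromethyl background. Going by these compounds alone, this position therefore accepts the added ethyl without a step beyond the scatter, whereas the earlier steps all concerned the aromatic substituent. No supporting data bear on why this is so.

Open, from the compounds shown here alone, is whether a longer chain, a cyclohexyl ring or an amine on this carbon would stay within the scatter. Also open, going by these compounds, is whether sec-butyl behaves alike with chloro on the aromatic carbon.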